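From 3-bromophenyl to 2-chlorophenyl: an estimate

This account rests on a few compounds, and the source may have more. Where it says the series, first, only, none or still open, it means among the compounds named here.

Compound 1 `Cc1cccc(Cn2cc(COc3ccc4c(=O)ccoc4c3)nn2)c1`: 11700 nM
Compound 2 `Cc1ccc(Cn2cc(COc3ccc4c(=O)ccoc4c3)nn2)cc1`: 10400 nM
Compound 3 `O=c1ccoc2cc(OCc3cn(Cc4cccc(Br)c4)nn3)ccc12`: > 100000 nM

In a functional assay on SW480 cells (Homo sapiens) for cytotoxicity, read by MTT assay, with a stated time of 48 h (a lower number here means a stronger inhibitor, a higher number a weaker inhibitor), compound 3 gives > 100000 nM, which is a limit of the assay and not a number. Compound 4 `O=c1ccoc2cc(OCc3cn(Cc4ccccc4Cl)nn3)ccc12` carries one change: 2-chlorophenyl in place of 3-bromophenyl on a saturated chain carbon bound to an aromatic nitrogen. The measured steps that bear on it are those into the 3-bromophenyl compound, an at least 8.5-fold higher number from compound 1 to compound 3 (0.93 log units; beyond the scatter) and an at least 9.6-fold higher number from compound 2 to compound 3 (0.98 log units; beyond the scatter). Within the data shown here, the step of a 1.1-fold lower number from compound 1 to compound 2 (0.05 log units; within the scatter) shows only that the two methyl compounds match. Among the measured compounds shown here, no chlorine-bearing compound has been measured, so a move back towards the methyl compounds is expected, though with wide uncertainty. The expected step is an at least 3.3-fold lower number from compound 3 to compound 4 (0.52 log units; beyond the scatter). For compound 4 the estimate is 30000 nM, with an expected range of 9000 nM to 100000 nM.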

Compound 4, half-maximal inhibitory concentration: 23500 nM
The estimate for compound 4 lay 1.3-fold (0.11 log units) above the measured number; measured number inside the range.
By their numbers in this assay, from the lowest: compounds 2, 1 and 4 (each within the scatter of the next, the first and the last beyond it). At a limit, above all of these: compound 3.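

Moving from 3-bromophenyl to 2-chlorophenyl brings a measurable number back (an at least 4.2-fold lower number from compound 3 to compound 4 (0.62 log units; beyond the scatter)), so a halogen on this ring does not by itself push a compound past the limit. The methyl compounds remain close to the chlorine compound, though the two comparisons read differently (a 2.0-fold higher number from compound 1 to compound 4 (0.30 log units; within the scatter); a 2.3-fold higher number from compound 2 to compound 4 (0.35 log units; beyond the scatter)). As far as these compounds go, the size of the first step stays open-ended, since compound 3 is a limit and not a number: the limit of > 100000 nM in this assay, at which 1 of the 4 values shown sits.

This change swaps the halogen and its ring position together, and the compounds shown do not separate the two. From the compounds shown here alone, how 3-chlorophenyl, or a ring carrying an amine or a carboxylic acid, would behave here remains open.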